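Adding (furan-2-yl)carbonyl to compound 3

This account rests on a few compounds, and the source may have more. Where it says the series, first, only, none or still open, it means among the compounds named here.

Measured in a functional assay on L5178Y cells (Mus musculus) for inhibition, read by MTT assay, with a stated time of 24 h; a higher number here means a weaker inhibitor, a lower number a stronger inhibitor:
Compound 1 `COc1cccc(/C=N/N=C2\C[C@@H](c3ccc(O)cc3)Oc3cc(OC)cc(O)c32)c1`: >= 11300 nM, a limit
Compound 2 `COc1cc(O)c2c(c1)O[C@H](c1ccc(O)cc1)C/C2=N\N`: >= 11300 nM, a limit
Compound 3 `COc1ccc([C@@H]2C/C(=N\N)c3c(O)cc(OC)cc3O2)cc1`: >= 11300 nM, a limit

Compound 3 has no number, only a limit, as do the other two compounds: the limit of >= 11300 nM in this assay, at which 3 of the 3 values shown sit. The change to compound 4 `COc1ccc([C@@H]2C/C(=N\NC(=O)c3ccco3)c3c(O)cc(OC)cc3O2)cc1` is (furan-2-yl)carbonyl in place of hydrogen on an amine nitrogen, with (furan-2-yl)carbonyl in place of hydrogen on an amine nitrogen. Going by the values given here, two measured steps bear on it: a step that the two limits leave unreadable from compound 1 to compound 2, which also changes a group on a nitrogen, and a step that the two limits leave unreadable from compound 2 to compound 3. Neither gives a size or a direction, so no step beyond the scatter is expected in this assay. The expected change is a step that the limit leaves unreadable from compound 3 to compound 4. For compound 4 the estimated value is 12000 nM, with an expected range from 5000 nM to 30000 nM.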

Compound 4, half-maximal inhibitory concentration: 2700 nM
For compound 4 the middle estimate is 4.4-fold (0.65 log units) above the measured one; measured number outside the range, below it.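

In this assay, (furan-2-yl)carbonyl in place of hydrogen on an amine nitrogen gives an at least 4.1-fold lower number from compound 3 to compound 4 (0.62 log units; beyond the scatter). Going by these compounds alone, the earlier steps cannot be read, so this is the first sign that a change at this nitrogen can shift the read-out, and the shift is towards a stronger inhibitor. Compound 4 is also the only compound shown with a number rather than a limit: the limit of >= 11300 nM in this assay, at which 3 of the 4 values shown sit.

Going by these compounds, what remains open is how much of the step belongs to the furan ring and how much to the carbonyl. On these data alone, whether acetyl or benzoyl on the same nitrogen would act alike also stays open, as does the full size of the step.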